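Fluoro in place of hydrogen on a low-stability scaffold

The source may report more compounds than this note shows. Statements on the series, on what has been measured and on what is new or still open speak of the compounds shown alone.

Going by the values given here, compound 2 `CCn1c(=O)/c(=C2\Sc3ccccc3N2C)s/c1=C\c1ccncc1` stands highest of the two numbers so far in an ADME assay on microsomes from liver (Mus musculus) for metabolic stability, with a stated time of 30 min (a higher number here means that more of the compound is left, a lower number that less of the compound is left), where compound 2 gives 6%. Compound 1 `CCn1c(=O)/c(=C2\Sc3cc(F)ccc3N2C)s/c1=C\c1ccccn1` in this assay gives 5%, a number within the scatter of compound 2, so no order between these two can be read and both numbers are low. Compound 3 `CCn1c(=O)/c(=C2\Sc3cc(F)ccc3N2C)s/c1=C\c1ccncc1` is reached from compound 2 by the change (fluoro in place of hydrogen on an aromatic carbon). Among the compounds with values here, no step between two measured compounds isolates this change, so its size is not known from the data. The expected step is a number 1 percentage points lower from compound 2 to compound 3 (within the scatter), nothing beyond the scatter, because compound 1 carrying the same fluoro gives 5% in this assay. Compound 3 is therefore estimated at 5% in this assay, with a range from 1% to 12%.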

Compound 3, percent of the compound remaining: 13%
Estimate against measurement, compound 3: 8 percentage points below, outside the stated range (above it).
By their numbers in this assay, from the lowest: compounds 1, 2 and 3 (each within the scatter of the next).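

In this assay, fluoro in place of hydrogen on an aromatic carbon, meta to a fused ring and para to a fused ring, now has a step of its own, a number 7 percentage points higher from compound 2 to compound 3 (within the scatter), so this change at this position shows no effect beyond the scatter. Pyridin-4-yl in place of pyridin-2-yl, with the fluoro kept, can also be read in isolation as a number 8 percentage points higher from compound 1 to compound 3 (within the scatter), and this change likewise does not separate the two compounds. No measured evidence bears on these results.

On these data alone, whether a larger group at the same aromatic carbon, such as methoxy or an amine, would give a step beyond the scatter in this assay stays open. The same holds for a longer chain in place of the ethyl group on the shared core.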